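A few compounds are considered here, and "the series" means these few. Any claim that something is new, unique, unknown or untested is made for them only; others in the source may bear on it.

Measured so far:
compound 1, `CCCCCCCCCCCCCC[C@@H](O)[C@@H](O)[C@H](CO)n1cc(CCCC)nn1`: 12900 nM
compound 2, `CCCCCCCCCCCCC/C=C/[C@@H](O)[C@H](CO)n1cc(CCCC)nn1`: 12900 nM
compound 3, `CCCCCCCCCCCCC/C=C/[C@@H](O)[C@H](CO)n1cc(CCCCCCCCCCCCCCCCCCCCCCCC)nn1`: > 50000 nM

All three were tested in a functional assay on HCT-116 cells (Homo sapiens) for cytotoxicity, read by sulforhodamine B assay; a higher number here means that more compound is needed for the effect, a lower number that less compound is needed. Compound 1 gives 12900 nM, and compound 2 gives 12900 nM, so the two stand level at the digits shown, within the usual scatter, and neither can be called the more potent. Compound 3 gives > 50000 nM, which is a limit of the assay and not a number, as noted in the limit of > 50000 nM in this assay, at which 1 of the 3 values shown sits.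

The unmeasured compound 4, `CCCCCCCCCCCCCC[C@@H](O)[C@@H](O)[C@H](CO)n1cc(CCC)nn1`, differs from compound 1 in a single place: hydrogen in place of methyl on a saturated chain carbon, three bonds along the chain from an aromatic carbon. Among the compounds with values here, no pair of measured compounds differs in just one place, so there is no measured step to read the size of this change from. The shortening of the chain on the triazole by one carbon is expected to produce no step beyond the scatter in this assay. Compound 4 is therefore expected to give about 15000 nM. Its estimated range runs from 6000 nM to 40000 nM. The expected step of a 1.2-fold higher number from compound 1 to compound 4 (0.07 log units; within the scatter) is small.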

Compound 4, half-maximal effective concentration: 13900 nM
Beside the measured number, compound 4's estimate is 1.1-fold (0.03 log units) above it; the range from low to high includes it.
By their numbers in this assay, from the lowest: compounds 1, 2 and 4 (each within the scatter of the next). At a limit, above all of these: compound 3.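

Within the data shown here, the step of a 1.1-fold higher number from compound 1 to compound 4 (0.03 log units; within the scatter) in this assay is the first measured between two compounds that differ in one place, so the effect of a change at this position can now be read directly rather than assumed. Going from butyl to propyl on this chain leaves compound 1 and compound 4 level, which shows that removing this one end carbon makes no readable difference to the cytotoxicity number. None of the measurements shown gives a reason for this result.

The compounds shown leave open whether the chain can be cut further, to an ethyl or a methyl, without a step beyond the scatter. They also leave open what an amine or a carboxylic acid at the end of this chain would do.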